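The compounds below may be only part of what the source reports. "The series", "measured", "known", "first", "only" and "open" are said of these compounds alone.

Compound 1 `COc1cc2c(/C=C3/C(=O)N(C)c4ccccc43)c(Cl)n(C)c2cc1C` and compound 2 `COc1cc2c(/C=C3/C(=O)N(C)c4ccc(O)cc43)c(Cl)n(C)c2cc1C` share one core, while compound 3 `COc1cc2c(/C=C3/C(=O)N(C)c4ccccc43)c[nH]c2cc1C` is built on a second core; the difference between the two cores is not broken down here. In a functional assay on cells (Cancer cell lines, Homo sapiens) for inhibition, with a stated time of 48 h (on this read-out higher numbers stand for weaker inhibition of growth and lower numbers for stronger inhibition of growth), compound 1 gives 8510 nM, compound 2 gives 3550 nM, and compound 3 gives 60300 nM, the highest of the three numbers, with each of its steps to the others lying beyond the scatter.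

The change from compound 1 to compound 2 is hydroxy in place of hydrogen on an aromatic carbon, and it brought a 2.4-fold lower number from compound 1 to compound 2 (0.38 log units; beyond the scatter).

Compound 4 `COc1cc2c(/C=C3/C(=O)N(C)c4ccc(O)cc43)c[nH]c2cc1C` has not yet been measured in this assay. It arises from compound 3 by hydroxy in place of hydrogen on an aromatic carbon, the same change placed on the second core. Going by the values given here, compound 4 is expected to show a 2.4-fold lower number from compound 3 to compound 4 (0.38 log units; beyond the scatter), because a 2.4-fold lower number from compound 1 to compound 2 (0.38 log units; beyond the scatter) is the only measured instance of this change and it stays modest. Compound 4 is therefore estimated at 25000 nM, with a likely range from 10000 nM to 60000 nM, and the weaker growth inhibition of the second core, seen in 60300 nM for compound 3, is expected to persist.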

Compound 4, concentration for total growth inhibition: 24600 nM
Compound 4: the middle estimate sits 1.0-fold (0.01 log units) above what was measured; measured number inside the range.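

On the second core, hydroxy in place of hydrogen on an aromatic carbon gave a 2.5-fold lower number from compound 3 to compound 4 (0.39 log units; beyond the scatter) in this assay. Set beside the earlier instance, the change carried over from one core to the other with a matching size: the same change on two cores in this assay, a 2.4-fold lower number (0.38 log units; beyond the scatter) from compound 1 to compound 2 and a 2.5-fold lower number (0.39 log units; beyond the scatter) from compound 3 to compound 4, 1.0-fold (0.01 log units) apart, within the scatter of two such steps. This shows that this one change, at this one place on the aromatic ring, behaves alike on these two cores in this one growth read-out, but two pairs set no rule for other cores or other groups and do not tell why the step has this size.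

The compounds shown leave open whether an amine or a carboxylic acid on the same aromatic carbon would give a step of similar size, or any step at all. They also leave open how the hydroxy step would run on any core other than these two.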